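Swapping an Aryl Ether for Cyclohexyl: Solubility Outlook

A few compounds are considered here, and "the series" means these few. Any claim that something is new, unique, unknown or untested is made for them only; others in the source may bear on it.

For the measured compounds named here, compound 3 `COc1cccc(Oc2ccc3c(NCCCNCc4ccco4)ccnc3c2)c1` stands second highest of the three compounds measured so far in a physicochemical assay for solubility, with a stated time of 18 h, at pH 7.4 (on this read-out higher numbers stand for higher solubility and lower numbers for lower solubility), where compound 3 gives 14500 nM. Compound 1 `CC(C)(C)c1ccc(-c2ccc3c(NCCCNCc4ccco4)ccnc3c2)cc1` gives 32000 nM, and compound 2 `c1coc(CNCCCNc2ccnc3cc(CC4CCCCC4)ccc23)c1` gives 4200 nM. Compound 4 `c1coc(CNCCCNc2ccnc3cc(C4CCCCC4)ccc23)c1` has not yet been measured; it differs from compound 3 by cyclohexyl in place of 3-methoxyphenoxy on an aromatic carbon. The measured step that bears most directly on this change is a 3.5-fold higher number from compound 2 to compound 3 (0.54 log units; beyond the scatter), with cyclohexylmethyl being a close relative of the entering cyclohexyl; the steps of a 7.6-fold lower number from compound 1 to compound 2 (0.88 log units; beyond the scatter) and a 2.2-fold lower number from compound 1 to compound 3 (0.34 log units; beyond the scatter) point the same way. Compound 4 is therefore expected to lose solubility by a modest step because a 3.5-fold higher number from compound 2 to compound 3 (0.54 log units; beyond the scatter) ran in the opposite direction. Compound 4 is estimated at 5000 nM, with a range from 2000 nM to 12000 nM. The expected step is a 2.9-fold lower number from compound 3 to compound 4 (0.46 log units; beyond the scatter).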

Compound 4, solubility: 4200 nM
The estimate for compound 4 lay 1.2-fold (0.08 log units) above the measured number; the measured number falls inside the stated range.
By their numbers in this assay, from the lowest: compounds 2 and 4 (each within the scatter of the next); then compound 3; then compound 1.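

On this aromatic carbon, cyclohexyl and cyclohexylmethyl cannot be told apart, with no change at the digits printed from compound 2 to compound 4 (within the scatter) in this assay. Both groups with a six-membered aromatic ring stand higher, giving a 3.5-fold lower number from compound 3 to compound 4 (0.54 log units; beyond the scatter) and a 7.6-fold lower number from compound 1 to compound 4 (0.88 log units; beyond the scatter), so among these four compounds the saturated rings sit together at the low end. Nothing measured here gives a reason for these steps. Still open, on these data alone, is whether an amine or a carboxylic acid at this position would move the number, and whether a longer chain carrying the cyclohexane ring would stay level with compound 2.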